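A few compounds are considered here, and "the series" means these few. Any claim that something is new, unique, unknown or untested is made for them only; others in the source may bear on it.

In a functional assay on Ehrlich cells (Mus musculus) for cytotoxicity, read by trypan blue exclusion, with a stated time of 2 h, tested at 5 ug/mL (a lower number here means a stronger effect, a higher number a weaker effect of the compound at the concentration tested), compound 1 `N#Cc1c(N)[n+]([O-])c2ccc(Cl)cc2[n+]1[O-]` gives 87.8%, and compound 2 `CNc1c(C#N)[n+]([O-])c2cc(Cl)ccc2[n+]1[O-]` gives 96%. These two numbers lie within the usual scatter of each other, so compound 2 cannot be told apart from compound 1 on the evidence here, and neither can be called the stronger or the weaker. Among the compounds with values here, the single measured step, a number 8.2 percentage points higher from compound 1 to compound 2 (within the scatter), where a methyl replaced a hydrogen on a nitrogen on an aromatic ring, stayed within the scatter. Compound 3 `CC(=O)N(C(C)=O)c1c(C#N)[n+]([O-])c2cc(Cl)ccc2[n+]1[O-]` differs from compound 2 by diacetylamino in place of methylamino on an aromatic carbon. This is a larger change than the methyl step, but nothing measured here points to a shift in either direction, so no step beyond the scatter is expected, a number 5 percentage points lower from compound 2 to compound 3 (within the scatter). Compound 3 is therefore estimated at 91% in this assay, within a range from 72% to 100%.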

Compound 3, a percentage reported as activity, at one concentration (the size of the read-out at that concentration, not a potency): 30.3%
Estimate against measurement, compound 3: 60.7 percentage points above; measured number below the stated range.
By their numbers in this assay, from the lowest: compound 3; then compounds 1 and 2 (each within the scatter of the next).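

In this assay, the aromatic carbon next to the ring nitrogen and ortho to the cyano group proves sensitive to what it carries: replacing methylamino with diacetylamino gives a number 65.7 percentage points lower from compound 2 to compound 3 (beyond the scatter), and replacing amino with diacetylamino gives a number 57.5 percentage points lower from compound 1 to compound 3 (beyond the scatter). Since a lower number means a stronger effect, this substituent brings a clear gain in effect at the tested concentration, which the small step between amino and methylamino gave no sign of. No information is available on what lies behind this large step.

The compounds shown leave open whether one acetyl on that nitrogen, as in acetylamino, would be enough, or whether both are needed. They also leave open whether longer acyl chains, such as two propanoyl groups, would keep the effect.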